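Triazine aminopyrimidine series: chloro-to-methyl swaps on the aniline and ether rings

A few compounds are considered here, and "the series" means these few. Any claim that something is new, unique, unknown or untested is made for them only; others in the source may bear on it.

Compound 1 `Cc1ccc(Nc2nc(N)nc(COc3ccc4c(C)cc(=O)oc4c3)n2)cc1Cl` and compound 2 `Cc1ccc(Nc2nc(N)nc(COc3ccc4c(C)cc(=O)oc4c3)n2)cc1C` share a core and differ only in one place: methyl in place of chloro on an aromatic carbon. In an assay on COS-7 cells for agonist activity at Free fatty acid receptor 1 (Homo sapiens), read by scintillation counting and inositol phosphate accumulation, with a stated time of 90 min (a higher number here means that more compound is needed for the effect, a lower number that less compound is needed), compound 1 gives 140 nM, and compound 2 gives 210 nM; the step of a 1.5-fold higher number from compound 1 to compound 2 (0.18 log units; within the scatter) is within the scatter, so the two values are read as the same.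

Compound 3 `Cc1ccc(Nc2nc(N)nc(COc3cc(N4CCCC4=O)ccc3Cl)n2)cc1Cl` carries a different aryl ether portion; the difference between the two cores is not broken down here. In this assay compound 3 gives "not determined" (no result reported), so there is no measured anchor on its own core. Compound 4 `Cc1ccc(Nc2nc(N)nc(COc3cc(N4CCCC4=O)ccc3C)n2)cc1Cl` differs from compound 3 by methyl in place of chloro on an aromatic carbon. Among the measured compounds shown here, this is the same kind of change as the one from compound 1 to compound 2, but the surroundings differ: in compound 1 the exchanged atom sits ortho to a methyl group and meta to a large group, while in compound 3 it sits ortho to a large group and para to a 2-oxopyrrolidin-1-yl group.

Because the step of a 1.5-fold higher number from compound 1 to compound 2 (0.18 log units; within the scatter) is within the scatter, the same kind of change on the ether ring is expected to leave the value close to where compound 3 would stand; with no number for compound 3, the expectation for compound 4 in this assay is taken from the measured core of compound 1 and compound 2 and is therefore broad, estimated at 200 nM, with the range 40 nM to 1000 nM.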

Compound 4, half-maximal effective concentration: 7450 nM
Estimate against measurement, compound 4: 37-fold (1.57 log units) below; the measured number lies above the stated range.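

Among the compounds shown here, compound 3 has no single number in this assay, and no step from it to compound 4 can be read. For the compounds shown here, what stays open is whether methyl in place of chloro, ortho to a large group and para to a 2-oxopyrrolidin-1-yl group, shifts the value at all, with compound 4 at 7450 nM the only number on its core. No supporting evidence bears on this result.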